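A few compounds are considered here, and "the series" means these few. Any claim that something is new, unique, unknown or untested is made for them only; others in the source may bear on it.

Measured compounds:
Compound 1, `C[C@H](NC(=O)c1c(C#Cc2ccc(=O)[nH]c2)sc2c1CCOC2)c1ccc(C(=O)O)cc1`, gives 642 nM.
Compound 2, `COc1ccc2cc(C#Cc3sc4c(c3C(=O)N[C@@H](C)c3ccc(C(=O)O)cc3)CCOC4)ccc2c1`, gives 27.2 nM.
Compound 3, `C[C@H](NC(=O)c1c(Cc2ccc(F)cc2)sc2c1CCOC2)c1ccc(C(=O)NN)cc1`, gives 74.9 nM.

All three were tested in a functional assay on CHO/Galpha16 cells for antagonist activity at prostaglandin E2 receptor EP4 subtype (Homo sapiens), read by calcium flux, with a stated time of 15 min; on this read-out lower numbers stand for stronger inhibition and higher numbers for weaker inhibition. On these numbers compound 1 stands highest of the three, weakest among them; compound 3 lies nearer to it and compound 2 furthest, and both gaps are beyond the scatter.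

Compound 4, `C[C@H](NC(=O)c1c(NC(=O)c2ccc(F)cc2)sc2c1CCOC2)c1ccc(C(=O)O)cc1`, has not yet been measured. Compared with compound 1 the change is a group of 10 heavy atoms (7 carbon, 1 nitrogen, 1 oxygen, 1 fluorine; one six-membered aromatic ring of carbon only) in place of a group of 9 heavy atoms (7 carbon, 1 nitrogen, 1 oxygen; one six-membered aromatic ring with 1 hetero atom), on an aromatic carbon. The group with the triple bond and the aromatic ring with one hetero atom leaves, and a ((4-fluorophenyl)carbonyl)amino group takes its place next to the ring sulfur of the shared core.

Within the data shown here, one measured step bears on this. The step of a 24-fold lower number from compound 1 to compound 2 (1.37 log units; beyond the scatter) also removed the aromatic ring with one hetero atom and brought in rings of carbon only, though it kept the triple bond. Compound 3 carries a fluorine-bearing ring as well, but it also differs in the acid end, so its value of 74.9 nM only hints that such a ring is tolerated. A lower number is therefore expected. The linker also changes in compound 4, and the expected step is taken to be smaller than that large one.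

Compound 4 is expected to give about 150 nM, between 40 nM and 500 nM. This estimate corresponds to an expected step of a 4.3-fold lower number from compound 1 to compound 4 (0.63 log units; beyond the scatter).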

Compound 4, half-maximal inhibitory concentration: > 1000 nM
Compound 4 was reported as a limit; the forecaster's own chance of this, stated with the estimate: 5%; middle value at least 6.6-fold (0.82 log units) away from the limit.
By their numbers in this assay, from the lowest: compound 2; then compound 3; then compound 1. At a limit, above all of these: compound 4.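

In this assay compound 4 is reported only as a limit and not as a number: the limit of > 1000 nM in this assay, at which 1 of the 4 values shown sits. Read against compound 1, the change gives an at least 1.5-fold higher number from compound 1 to compound 4 (0.19 log units; that floor lies within the scatter), so the two cannot be firmly ranked, but a clearly lower number can be ruled out for the ((4-fluorophenyl)carbonyl)amino group at this position next to the ring sulfur. The earlier step, a 24-fold lower number from compound 1 to compound 2 (1.37 log units; beyond the scatter), might have suggested that losing the aromatic ring with a hetero atom and bringing in a ring of carbon only was enough for a gain, whereas this result shows that such a ring does not bring one regardless of what joins it to the shared core.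

On these data alone, what remains open is how far the true value of compound 4 lies past its limit, and so whether this change costs activity at all or leaves it about where compound 1 stands. As far as these compounds go, it also remains open whether the missing gain belongs to the ring or to the link, which a 4-fluorophenyl group on a triple-bonded carbon, with the carboxylic acid end of compound 1 kept, could help to separate.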